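This account rests on a few compounds, and the source may have more. Where it says the series, first, only, none or still open, it means among the compounds named here.

Values in a functional assay on Bel7402/5-FU cells (Homo sapiens) for antiproliferative activity, read by MTT assay, with a stated time of 72 h; on this read-out higher numbers stand for weaker inhibition and lower numbers for stronger inhibition:

- Compound 1 `C=C1C(=O)O[C@H]2[C@H]1CC/C(COC(=O)CCC(=O)N1CCN(C(=O)Cn3cc(F)c(=O)[nH]c3=O)CC1)=C\CC[C@@]1(C)O[C@@H]21`: > 20000 nM (a limit)
- Compound 2 `C=C1C(=O)O[C@H]2[C@H]1CC/C(COC(=O)Cn1cc(F)c(=O)n(Cc3ccc(F)cc3)c1=O)=C\CC[C@@]1(C)O[C@@H]21`: 1140 nM
- Compound 3 `C=C1C(=O)O[C@H]2[C@H]1CC/C(COC(=O)Cn1cc(F)c(=O)n(Cc3ccc(Cl)cc3)c1=O)=C\CC[C@@]1(C)O[C@@H]21`: 2420 nM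

Compound 1 stands only as a limit, > 20000 nM, and not as a number. Among the measured compounds shown here, no single-place step connects it with the other compounds, so it gives no guidance here.

Compound 3, at 2420 nM, has the higher of the two true numbers in this assay, which makes it the weaker inhibitor of that pair. For the measured compounds named here, its only measured neighbour is compound 2, and chloro in place of fluoro on an aromatic carbon gave a 2.1-fold higher number from compound 2 to compound 3 (0.33 log units; beyond the scatter).

Compound 4 `C=C1C(=O)O[C@H]2[C@H]1CC/C(COC(=O)Cn1cc(F)c(=O)n(Cc3ccc([N+](=O)[O-])cc3)c1=O)=C\CC[C@@]1(C)O[C@@H]21` carries nitro in place of chloro on an aromatic carbon, para to a large group: nitro in place of chloro on an aromatic carbon. The 4-chlorobenzyl group thus becomes 4-nitrobenzyl.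

The fluoro-to-chloro step is the only measured one that bears on this change, and it was modest. A single step cannot set a direction for a different substituent, so a change of similar modest size or smaller is expected in this assay, with either sign possible.

The expected change is a 1.2-fold lower number from compound 3 to compound 4 (0.08 log units; within the scatter). For compound 4 the estimated value is 2000 nM, with an expected range of 700 nM to 6000 nM.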

Compound 4, half-maximal inhibitory concentration: 4340 nM
Estimate against measurement, compound 4: 2.2-fold (0.34 log units) below, within the range that was stated.
By their numbers in this assay, from the lowest: compound 2; then compounds 3 and 4 (each within the scatter of the next). At a limit, above all of these: compound 1.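

Nitro in place of chloro on the aromatic carbon, para to a large group, gave a 1.8-fold higher number from compound 3 to compound 4 (0.25 log units; within the scatter) in this assay, so these two groups cannot be told apart at this position. Nitro in place of fluoro gave a 3.8-fold higher number from compound 2 to compound 4 (0.58 log units; beyond the scatter), which joins a 2.1-fold higher number from compound 2 to compound 3 (0.33 log units; beyond the scatter) as a second step beyond the scatter and shows that, among compounds 2, 3 and 4, the 4-fluorobenzyl group alone stands apart, with the lowest number of the three. Nothing given here accounts for these differences between the three groups.

With only fluoro, chloro and nitro at this position, the compounds shown leave open how far the number would move with an amine or a carboxylic acid on the same carbon, or with a plain benzyl group carrying no substituent there. They also leave open whether fluoro would keep its place in this series if the benzyl group gave way to a longer chain between the ring and the core.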